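Mirror image of compound 1 in rat microsomes

A few compounds are considered here, and "the series" means these few. Any claim that something is new, unique, unknown or untested is made for them only; others in the source may bear on it.

Measured so far in an ADME assay on liver for metabolic stability, with Liver microsome (Rattus norvegicus) as the target, read by LC-MS, using microsomes, with a stated time of 5 h; on this read-out lower numbers stand for slow clearance and higher numbers for fast clearance (values follow each structure):
compound 1 `C[C@]1(c2ccc(OC(F)(F)F)cc2)C[C@@](O)(c2ccccn2)CO1` gives 150 mL/min/kg
compound 2 `C[C@]1(O)C[C@@](c2cccc(C(F)(F)F)c2)([C@H](O)c2ccccn2)C1` gives 317 mL/min/kg
compound 3 `OC(c1ccccn1)C1(c2ccc(C(F)(F)F)cc2)CNC1` gives 50 mL/min/kg

Compound 1 stands second highest of the three numbers in this assay with its 150 mL/min/kg reading. Compound 2 lies above it and compound 3 below it, both gaps beyond the usual scatter.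

The next compound is compound 4 `C[C@@]1(c2ccc(OC(F)(F)F)cc2)C[C@](O)(c2ccccn2)CO1` and it is the mirror image of compound 1. The change is the two compounds have the same atoms and bonds and differ only in configuration as drawn: 2 of 2 stereo elements differ (all stereocentres are inverted: mirror images); a stereocentre at a saturated ring carbon is drawn R in compound 1 and S in compound 4; a stereocentre at a saturated ring carbon is drawn R in compound 1 and S in compound 4 (same atoms and bonds, all stereocentres inverted).

Among the compounds with values here, no measured pair here differs in one place, and no measured pair differs in configuration alone. The series therefore gives no direct measure of what inversion does to this read-out. Compounds 2 and 3 differ from compound 1 in more than configuration and offer no guide to direction.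

Within the data shown here, the only anchor is compound 1 at 150 mL/min/kg and no direction can be favoured. The expected no change at the digits printed from compound 1 to compound 4 (within the scatter) is none beyond the scatter, though a mirror pair may still separate, so the range is kept wide. Compound 4 is estimated at 150 mL/min/kg with an expected range from 75 mL/min/kg to 300 mL/min/kg when it is measured.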

Compound 4, clearance: 383 mL/min/kg
Estimate against measurement, compound 4: 2.6-fold (0.41 log units) below, and the stated range ends below it.
By their numbers in this assay, from the lowest: compound 3; then compound 1; then compounds 2 and 4 (each within the scatter of the next).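

Working notes on the mirror pair: in this assay, the read-out separates the two mirror images of the shared core, with a 2.6-fold higher number from compound 1 to compound 4 (0.41 log units; beyond the scatter) and no atom or bond altered. Within the data shown here, this is the first direct measure of configuration, as the earlier compounds differ from compound 1 in more than configuration and could not isolate it. The step can be assigned to configuration alone, and not to any group, because of this: the fact that compounds 1 and 4 differ only in the configuration as drawn.

The two stereocentres are inverted together, so the compounds shown leave open whether one of them carries the step or both contribute, a question that a diastereomer of compound 1 with a single inverted centre would address. Also open, on these data alone, is whether the gap between the mirror images persists when the core is otherwise changed, for example with a nitrile in place of the trifluoromethoxy group, and the pair gives no information on which structural feature of compound 4 is linked to its higher number.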